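This account rests on a few compounds, and the source may have more. Where it says the series, first, only, none or still open, it means among the compounds named here.

Measured so far in a functional assay on L1210 cells (Mus musculus) for cytotoxicity, with a stated time of 48 h; a higher number here means a weaker inhibitor, a lower number a stronger inhibitor:
compound 1 `Clc1ccc(Cc2nn3cc(-c4ccc(Br)cc4)nc3s2)cc1`: > 250000 nM, which is a limit of the assay
compound 2 `Clc1ccc(Cc2nn3c(Br)c(-c4ccc(Cl)cc4)nc3s2)cc1`: > 250000 nM, which is also a limit of the assay

Compound 2 stands at the limit of this assay: its value is not a number but the boundary of what the assay reports. Among the compounds with values here, the one further value shown is of the same kind, so the series sits entirely at the limit of > 250000 nM in this assay, at which 2 of the 2 values shown sit. Within the data shown here, no step between measured compounds that differ in one place exists here, and therefore no measured effect of any single structural change is known for this assay.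

Compound 3 `Clc1ccc(Cc2nn3c(Br)c(-c4ccc(Br)cc4)nc3s2)cc1` differs from compound 2 by bromo in place of chloro on an aromatic carbon. With both shown values resting at the limit, the measured compounds give no direction and no size to read from. The expected step in this assay is a step that the limit leaves unreadable from compound 2 to compound 3, none beyond the usual scatter. Compound 3 is therefore estimated at 300000 nM, with a range of 100000 nM to 1000000 nM, and is most likely to be reported again only as a limit rather than a number.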

Compound 3, half-maximal inhibitory concentration: > 250000 nM
Compound 3: no number, only a limit; the forecaster's own chance of this, stated with the estimate: 85%; the middle value is on the limit's open side.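

Compound 3 adds no readable step: the steps to it from compound 1 and from compound 2 cannot be read, because all the values rest on one limit: the limit of > 250000 nM in this assay, at which 3 of the 3 values shown sit.

The compounds shown leave open whether any change on the shared core moves the read-out in this assay at all, and in which direction and by how much.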